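The source may hold more compounds than are shown below. What is called first, only, known or untested is meant among the compounds shown, and "the series" means these compounds.

Compound 1 `Cc1nc(-c2ccccc2)c(C(=O)N2CCN(c3cccc(C)c3C)CC2)o1`, compound 2 `C=C(C)c1ccc(N2CCN(C(=O)c3oc(C)nc3-c3ccccc3)CC2)cc1`, compound 3 `COc1cccc(N2CCN(C(=O)c3oc(C)nc3-c3ccccc3)CC2)c1` and compound 4 `Cc1nc(-c2ccccc2)c(C(=O)N2CCN(c3ccc(F)cc3)CC2)o1` share a core and differ in the group on an amine nitrogen in a ring. Within the data shown here, in a functional assay on HL-60 cells (Homo sapiens) for inhibition, read by MTT assay, with a stated time of 72 h (on this read-out higher numbers stand for weaker inhibition and lower numbers for stronger inhibition), compound 1 gives 35 nM and compound 3 gives 34.8 nM, so compound 3 stands level with the only other number available. Compound 2 gives "not active" (no number reported), so a change at this place can also leave no number at all.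

The next change is made on compound 3: 4-fluorophenyl in place of 3-methoxyphenyl on an amine nitrogen in a ring. Put simply, 4-fluorophenyl comes in place of 3-methoxyphenyl on an amine nitrogen in a ring. Among the measured compounds shown here, only one measured step bears on this, the exchange of 2,3-dimethylphenyl for 3-methoxyphenyl at the same place, a 1.0-fold lower number from compound 1 to compound 3 (0.00 log units; within the scatter). That step lies within the scatter, but it rests on a single pair, and the entering group has not been measured in this series. No clear step is therefore expected in this assay. The result for compound 2, "not active" (no number reported), tilts the expectation slightly towards a higher number and widens the range. The estimated change is a 1.4-fold higher number from compound 3 to compound 4 (0.16 log units; within the scatter). For compound 4 the expected value is 50 nM, with an estimated range from 12 nM to 250 nM.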

Compound 4, half-maximal inhibitory concentration: > 1000 nM
Compound 4: only a limit was reported; the forecaster's own chance of this, stated with the estimate: 20%; middle value at least 20-fold (1.30 log units) away from the limit.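

Until now, this position on the ring nitrogen looked undemanding, since exchanging one aryl group for another in this assay gave a 1.0-fold lower number from compound 1 to compound 3 (0.00 log units; within the scatter). Compound 4 shows that the position is far from indifferent to the group it carries, with 4-fluorophenyl giving an at least 28-fold higher number from compound 3 to compound 4 (1.45 log units; beyond the scatter) and, measured against the other active compound, an at least 28-fold higher number from compound 1 to compound 4 (1.45 log units; beyond the scatter). For compound 4, > 1000 nM is a limit of the assay and not a number, and the full size of both steps stays unknown because the reading ends at that limit: the limit of > 1000 nM in this assay, at which 1 of the 4 values shown sits.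

The compounds shown do not separate the effect of the fluorine itself from that of its place on the phenyl ring, since 4-fluorophenyl differs from 3-methoxyphenyl in both respects. A 3-fluorophenyl group and a 4-methoxyphenyl group would each change only one of these features, and an unsubstituted phenyl group would show where the series stands with neither fluorine nor methoxy present.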